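The compounds below may be only part of what the source reports. "The series", "measured", "known", "first", "only" and "open" are said of these compounds alone.

Measured compounds in an assay on HEK293 cells for agonist activity at transient receptor potential cation channel subfamily M member 8 (Homo sapiens), read by fluorescence and calcium flux, with a stated time of 15 min; a lower number here means that less compound is needed, a higher number that more compound is needed for the effect:
- compound 1, `Cc1ccc(OCC(=O)N(Cc2cccs2)c2c[nH]nc2C)cc1`, gives 0.4 nM
- compound 2, `CCN(Cc1cccs1)C(=O)COc1ccc(OC)cc1`, gives 120 nM

Compound 1 has the lowest number of the two, so the least compound is needed for the effect. Its nearest neighbour is compound 2, which needs a far higher amount, a gap well beyond the usual scatter of repeated measurements. The two differ in several places at once, so no single change can be read from that pair; only the two values themselves are known.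

Compound 3, `Cc1ccc(OCC(=O)N(Cc2cccs2)c2ccn(C)n2)cc1`, has not yet been measured. It keeps all the atoms of compound 1 but joins them differently: 1-methyl-1H-pyrazol-3-yl in place of 3-methyl-1H-pyrazol-4-yl on an amide-type nitrogen. The group that leaves and the group that enters are the same size, yet the ring is attached through a different position and the methyl has moved from a ring carbon to a ring nitrogen.

For the measured compounds named here, no measured pair shows this exact change, so the expected step is uncertain. The number for compound 3 is expected to rise, by a 25-fold higher number from compound 1 to compound 3 (1.40 log units; beyond the scatter), a loss beyond the scatter. Compound 3 is therefore estimated at 10 nM, within a range from 1 nM to 200 nM.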

Compound 3, half-maximal effective concentration: 855 nM
For compound 3 the middle estimate is 86-fold (1.93 log units) below the measured one, outside the stated range (above it).
By their numbers in this assay, from the lowest: compound 1; then compound 2; then compound 3.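

In this assay, for the compounds shown here, putting 1-methyl-1H-pyrazol-3-yl in place of 3-methyl-1H-pyrazol-4-yl on the amide-type nitrogen gives a 2100-fold higher number from compound 1 to compound 3 (3.33 log units; beyond the scatter), the first change in this set that can be read at a single place. The two groups have the same size and the same atoms, so this position is sensitive to how the group is put together, not only to what it contains. The attachment point of the ring and the place of the methyl both differ, and the leaving group has 1 hydrogen-bond donor where the entering group has 0 hydrogen-bond donors, but no measurement here links the step to any one of these differences.

The compounds shown leave open whether the ring attachment or the methyl position matters more, as the two change together in this single step. They also leave open how this position would respond to a different group on the same nitrogen, such as a phenyl ring or an unsubstituted pyrazolyl group, which would show how much of the low number of compound 1 depends on its own ring.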